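A few compounds are considered here, and "the series" means these few. Any claim that something is new, unique, unknown or untested is made for them only; others in the source may bear on it.

Measured in an ADME assay on Jejunum (Mus musculus, strain C57BL/6) for metabolic stability, read by HPLC, with a stated time of 12 h; a higher number here means that the compound lasts longer, a lower number that the compound disappears faster:
Compound 1 `O=C(O)[C@H](CO)NC(=O)[C@H]1C[C@@H](O)CN1`: > 12 h (a limit of the assay, not a number)
Compound 2 `O=C(O)[C@H](CO)NC(=O)[C@@H]1C[C@H](O)CN1`: 0.39 h

Among the compounds with values here, compound 2 holds the only true number so far, 0.39 h. Within the data shown here, the one measured step, an at least 30-fold lower number from compound 1 to compound 2 (1.48 log units; beyond the scatter), is large, and it comes with the fact that compounds 1 and 2 differ only in the configuration as drawn. Compound 3 `O=C(N[C@H](CO)C(=O)O)[C@@H]1C[C@@H](O)CN1` is again a change of shape only: the two compounds have the same atoms and bonds and differ only in configuration as drawn: 2 of 3 stereo elements differ; a stereocentre at a saturated chain carbon is drawn S in compound 2 and R in compound 3; a stereocentre at a saturated ring carbon is drawn S in compound 2 and R in compound 3, with one saturated chain carbon and one saturated ring carbon drawn R instead of S. The step from compound 1 touched ring carbons only, so it is a loose guide, but it shows that configuration alone can move this half-life far. A clear rise is therefore expected, though with wide uncertainty, and the expected change is a 7.7-fold higher number from compound 2 to compound 3 (0.89 log units; beyond the scatter). Compound 3 is estimated at 3 h, with an expected range of 0.5 h to 12 h.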

Compound 3, half-life: 0.33 h
Compound 3: the middle estimate sits 9.1-fold (0.96 log units) above what was measured; the whole stated range lies above it.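

In this assay turning the chain carbon and a ring carbon together gives a 1.2-fold lower number from compound 2 to compound 3 (0.07 log units; within the scatter) so a change of configuration alone need not move this half-life. Compound 1 stands apart, with an at least 36-fold lower number from compound 1 to compound 3 (1.56 log units; beyond the scatter) and this large gap arises with no change in atoms or bonds: the fact that compounds 1 and 3 differ only in the configuration as drawn

From the compounds shown here alone, each pair differs at two stereo elements, and which single one matters stays open. Also open, going by these compounds, is how the half-life would respond to a fluorine atom in place of the ring hydroxyl.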